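Compound 3: 2-chloro-4-fluorophenyl for 4-bromophenyl

This account rests on a few compounds, and the source may have more. Where it says the series, first, only, none or still open, it means among the compounds named here.

In a functional assay on SW-620 cells (Homo sapiens) (a higher number here means a weaker inhibitor of growth, a lower number a stronger inhibitor of growth), compound 1 `N#Cc1ccc(/C=C/S(=O)(=O)Cc2ccc(Nc3ncnc4ccccc34)cc2)cc1` gives > 100000 nM, which is a limit of the assay and not a number. Compound 2 `O=S(=O)(/C=C/c1ccc(Br)cc1)Cc1ccc(Nc2ncnc3ccccc23)cc1` gives > 100000 nM, also a limit. Compound 2 therefore has no numerical position in the series, and the limit of > 100000 nM in this assay, at which 2 of the 2 values shown sit, describes both compounds.

Compound 3 `O=S(=O)(/C=C/c1ccc(F)cc1Cl)Cc1ccc(Nc2ncnc3ccccc23)cc1` carries 2-chloro-4-fluorophenyl in place of 4-bromophenyl, on a double-bonded chain carbon bound to a double-bonded chain carbon: 2-chloro-4-fluorophenyl in place of 4-bromophenyl on a double-bonded chain carbon bound to a double-bonded chain carbon.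

Going by the values given here, the only measured step bearing on this is a step that the two limits leave unreadable from compound 1 to compound 2, with bromo in place of cyano on an aromatic carbon. It offers no size to carry over, so no step beyond the scatter is expected in this assay, and another limit is the likeliest report. The expected step is a number no higher from compound 2 to compound 3 (the limit leaves the size open). For compound 3 the estimate is 100000 nM, with an expected range of 40000 nM to 200000 nM.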

Compound 3, concentration for 50% growth inhibition: 100000 nM
Beside the measured number, compound 3's estimate shows no gap at the digits printed, and the stated range covers the measured number.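

In this assay, going by these compounds alone, compound 3 gives 100000 nM as the first actual number, so 2-chloro-4-fluorophenyl at this position yields a reading where the earlier groups yielded none. Compound 2 gives > 100000 nM as a limit of the assay and not a number. The change to 2-chloro-4-fluorophenyl gives a number no higher from compound 2 to compound 3 (the limit leaves the size open) and a number no higher from compound 1 to compound 3 (the limit leaves the size open). Neither step can be read as a size, and most of the series still rests on one limit: the limit of > 100000 nM in this assay, at which 2 of the 3 values shown sit.

Open, from the compounds shown here alone, is whether the chloro or the fluoro group alone would give a number in this assay and whether any change here reaches values clearly apart from that limit. A phenyl ring carrying a dimethylamino group or a carboxylic acid at this position would test that further.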